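The source may hold more compounds than are shown below. What is called first, only, known or untested is meant among the compounds shown, and "the series" means these compounds.

In a functional assay on Vero cells (Chlorocebus sabaeus) for inhibition (on this read-out higher numbers stand for weaker inhibition and lower numbers for stronger inhibition), compound 2 `COc1cc(/C=C/C(=O)c2cccc(NC(=O)c3ccc(Cl)c(Cl)c3)c2)ccc1O` gives > 50 ug/mL, which is a limit of the assay and not a number. Its two measured relatives have real numbers: compound 1 `COc1cc(/C=C/C(=O)c2cccc(NC(=O)c3c(Cl)cccc3Cl)c2)ccc1O` gives 2.48 ug/mL and compound 3 `COc1cc(/C=C/C(=O)c2cccc(NC(=O)c3ccccc3)c2)ccc1O` gives 3.47 ug/mL. These two do not differ meaningfully, with a 1.4-fold higher number from compound 1 to compound 3 (0.15 log units; within the scatter).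

The next compound, compound 4 `COc1cc(/C=C/C(=O)c2cccc(NC(C)=O)c2)ccc1O`, comes from compound 2 by one change: methyl in place of 3,4-dichlorophenyl on a carbonyl carbon. This puts methyl in place of 3,4-dichlorophenyl on a carbonyl carbon, so the (3,4-dichlorophenyl)carbonyl becomes acetyl.

Going by the values given here, two measured steps bear on this. The closest also removes the 3,4-dichlorophenyl from that carbon, and it is an at least 14-fold lower number from compound 2 to compound 3 (1.15 log units; beyond the scatter). The other brings that group in, and it is an at least 20-fold higher number from compound 1 to compound 2 (1.30 log units; beyond the scatter). Among the compounds with values here, both are large, so a large move towards a lower number is expected in this assay, although no measured compound carries methyl there. The expected step is an at least 8.3-fold lower number from compound 2 to compound 4 (0.92 log units; beyond the scatter). The estimate for compound 4 is 6 ug/mL, with an expected range from 1.5 ug/mL to 30 ug/mL.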

Compound 4, half-maximal inhibitory concentration: 14.5 ug/mL
The estimate for compound 4 lay 2.4-fold (0.38 log units) below the measured number; measured number inside the range.
By their numbers in this assay, from the lowest: compounds 1 and 3 (each within the scatter of the next); then compound 4. At a limit, above all of these: compound 2.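

In this assay, a ring on this carbonyl carbon turns out not to be needed for a measurable number, since the change from 3,4-dichlorophenyl to the much smaller methyl gives an at least 3.4-fold lower number from compound 2 to compound 4 (0.53 log units; beyond the scatter). Methyl does not match the other two rings, however, with a 4.2-fold higher number from compound 3 to compound 4 (0.62 log units; beyond the scatter) and a 5.8-fold higher number from compound 1 to compound 4 (0.77 log units; beyond the scatter), so phenyl and 2,6-dichlorophenyl both give lower numbers than methyl, while compound 2 goes against this pattern. Compound 2 stands at a limit and not at a number, so its step gives only a minimum size: the limit of > 50 ug/mL in this assay, at which 1 of the 4 values shown sits.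

The compounds shown leave open whether a longer chain, such as propyl, would land nearer methyl or nearer phenyl. They also leave open how an amine or a carboxylic acid on this carbonyl carbon would compare, and whether a single chlorine on the phenyl would raise the number as the 3,4-dichlorophenyl does.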